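The source may report more compounds than this note shows. Statements on the series, on what has been measured and on what is new or still open speak of the compounds shown alone.

Measured in a functional assay on PC-3 cells (Homo sapiens) for cytotoxicity, read by MTT assay, with a stated time of 72 h; on this read-out higher numbers stand for weaker inhibition and lower numbers for stronger inhibition:

- Compound 1 `COc1cc2ncnc(Nc3ccc(F)c(Cl)c3)c2cc1NC(=O)N/N=C/c1cccc(Cl)c1Cl`: 24400 nM
- Compound 2 `COc1cc2ncnc(Nc3ccc(F)c(Cl)c3)c2cc1NC(=O)N/N=C/c1cc(OC)c(OC)c(OC)c1`: 36500 nM

Compound 2, at 36500 nM, cannot be told apart from compound 1 on these numbers, since the two values lie within the scatter of each other. Compound 3 `COc1cc2ncnc(Nc3ccc(F)c(Cl)c3)c2cc1NC(=O)N/N=C/c1ccc(O)cc1O` keeps the shared core and carries 2,4-dihydroxyphenyl in place of 3,4,5-trimethoxyphenyl on a carbon with a double bond to nitrogen.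

Going by the values given here, only one measured step bears on this change. It is an exchange at the same place, 3,4,5-trimethoxyphenyl in place of 2,3-dichlorophenyl, and it amounts to a 1.5-fold higher number from compound 1 to compound 2 (0.17 log units; within the scatter). That single step is small, but neither measured compound carries a 2,4-dihydroxyphenyl, so the evidence is thin and the range must stay wide. In this assay, no change beyond the scatter is therefore expected, with the expected step being a 1.3-fold lower number from compound 2 to compound 3 (0.12 log units; within the scatter). For compound 3 the estimated value is 28000 nM, with an expected range from 10000 nM to 75000 nM.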

Compound 3, half-maximal inhibitory concentration: 29500 nM
Compound 3: the middle estimate sits 1.1-fold (0.02 log units) below what was measured, and the stated range covers the measured number.
By their numbers in this assay, from the lowest: compounds 1, 3 and 2 (each within the scatter of the next).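

In this assay, 2,4-dihydroxyphenyl in place of 3,4,5-trimethoxyphenyl on a carbon with a double bond to nitrogen comes to a 1.2-fold lower number from compound 2 to compound 3 (0.09 log units; within the scatter), and 2,4-dihydroxyphenyl in place of 2,3-dichlorophenyl comes to a 1.2-fold higher number from compound 1 to compound 3 (0.08 log units; within the scatter). The earlier pair had compared only the dichloro and trimethoxy groups, neither of which carries a hydrogen-bond donor; with the 2,4-dihydroxyphenyl, hydrogen-bond donors now enter at this place, and the three compounds still cannot be told apart on these numbers. Nothing measured here accounts for how closely these values lie together.

The compounds shown leave open whether any group at this place would move the number beyond the scatter, since all three carry a substituted phenyl ring; a dimethylamino group or a carboxylic acid on that ring, or a plain alkyl chain in place of the ring, would test this. They also leave open whether the same closeness would hold for a single hydroxy or a single methoxy group on the phenyl ring, and whether it would hold on any other cell line.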